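A few compounds are considered here, and "the series" means these few. Any claim that something is new, unique, unknown or untested is made for them only; others in the source may bear on it.

Working notes on the series. Three analogues share one core. Compound 1 `Oc1cccc(-c2cc(-c3ccncc3)nc(-c3cccc(Cl)c3)c2)c1` in a functional assay on DU-145 cells (Homo sapiens) for cytotoxicity, read by CCK-8 assay and cell counting, with a stated time of 2 days (on this read-out higher numbers stand for weaker inhibition and lower numbers for stronger inhibition), gives "not determined" (no result reported), so no number exists for it. Compound 2 `Oc1cccc(-c2cc(-c3cccc(Cl)c3)nc(-c3ccccn3)c2)c1` in this assay likewise gives "not determined" (no result reported), so no number exists for it either. Among the compounds with values here, compound 3 `Oc1cccc(-c2cc(-c3cccc(Cl)c3)nc(-c3ccco3)c2)c1` is the only member with a figure: in this assay compound 3 gives 2020 nM, and with nothing else measured it cannot be placed relative to the others. The next entry, compound 4 `Oc1cccc(-c2cc(-c3ccsc3)nc(-c3cccc(Cl)c3)c2)c1`, differs from compound 3 in one spot: thiophen-3-yl in place of furan-2-yl on an aromatic carbon. Within the data shown here, no measured pair shows what this exchange of one five-membered ring for another does. The step from compound 3 to compound 4 is therefore expected to be small, a 1.0-fold lower number from compound 3 to compound 4 (0.00 log units; within the scatter), not clearly beyond the scatter in either direction. Compound 4 is estimated at 2000 nM, with a range of 700 nM to 6000 nM.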

Compound 4, half-maximal inhibitory concentration: 3330 nM
Compound 4: middle estimate off by 1.7-fold (0.22 log units), on the low side; the range from low to high includes it.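

In this assay, within the data shown here, the step of a 1.6-fold higher number from compound 3 to compound 4 (0.22 log units; within the scatter) gives the first measured pair at this position, on an aromatic carbon next to the ring nitrogen. Exchanging furan-2-yl for thiophen-3-yl, with sulfur taking the place of oxygen as the hetero atom of the five-membered aromatic ring, stays within the scatter in this read-out. No data on any property of these two groups bear on this result. Open, from the compounds shown here alone, is how a group other than a five-membered aromatic ring behaves at this position. An amine or a carboxylic acid there could show whether the read-out tolerates more than this exchange.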